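Dropping the Chloro Group from an Inactive Analog

The source may report more compounds than this note shows. Statements on the series, on what has been measured and on what is new or still open speak of the compounds shown alone.

Compound 1 `Cn1cc(C2=C(c3n[nH]c4ncccc34)C(=O)N(c3cccc4ccccc34)C2=O)c2ccccc21` was tested in a functional assay on SMMC-7721 cells (Homo sapiens) for antiproliferative activity, read by MTT assay, with a stated time of 48 h (a higher number here means a weaker inhibitor, a lower number a stronger inhibitor), and returned only a limit of the assay, > 100000 nM. Compound 2 `Cn1cc(C2=C(c3nn(CCCN4CCCCC4)c4ncccc34)C(=O)N(c3ccc(Cl)cc3)C2=O)c2ccccc21` likewise returned only a limit in this assay, > 100000 nM. Both results sit at the limit of > 100000 nM in this assay, at which 2 of the 2 values shown sit, so compound 2 stands at the limit itself, with no number to place it against anything. Compound 3 `Cn1cc(C2=C(c3nn(CCCN4CCCCC4)c4ncccc34)C(=O)N(c3ccccc3)C2=O)c2ccccc21` carries the change (hydrogen in place of chloro on an aromatic carbon). The step of a number no higher from compound 2 to compound 3 (the limit leaves the size open) is expected to stay within the scatter of repeated measurement. Compound 3 is therefore expected to give about 100000 nM, within 30000 nM to 300000 nM, most likely again reported only as a limit.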

Compound 3, half-maximal inhibitory concentration: 3050 nM
Beside the measured number, compound 3's estimate is 33-fold (1.52 log units) above it; measured number below the stated range.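

In this assay the change from 4-chlorophenyl to phenyl gives an at least 32-fold lower number from compound 2 to compound 3 (1.51 log units; beyond the scatter), so what this aromatic carbon, para to a large group, carries makes a clear difference. The earlier compounds shown here gave only limits, with no number to set anything against. The full size of the step stays open, because compound 2 carries only a limit: the limit of > 100000 nM in this assay, at which 2 of the 3 values shown sit.

The compounds shown leave open whether a fluoro group, a methoxy group or an amine at this position would behave like chloro or like hydrogen. This single pair also cannot say whether the same change would matter with another chain in place of the piperidine-bearing propyl chain.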